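A New Ring on the Carbonyl of Compound 3

A few compounds are considered here, and "the series" means these few. Any claim that something is new, unique, unknown or untested is made for them only; others in the source may bear on it.

Of the compounds shown here, three sharing one core have been measured in a physicochemical assay for solubility, read by LC-MS, in phosphate buffer, with a stated time of 24 h, at pH 6.8; a higher number here means a more soluble compound, a lower number a less soluble compound. Compound 1 `C[C@@H](c1ccc(NC(=O)N2CC(c3cccnc3)C2)cc1)N1Cc2ccccc2C1=O` gives 130000 nM, compound 2 `C[C@H](NC(=O)c1ncccn1)c1ccc(NC(=O)N2CC(c3cccnc3)C2)cc1` gives 930000 nM, and compound 3 `C[C@H](NC(=O)C1CCOCC1)c1ccc(NC(=O)N2CC(c3cccnc3)C2)cc1` gives 380000 nM. Compound 3 therefore stands in the middle, below compound 2 and above compound 1, with both gaps beyond the usual scatter.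

Compound 4 `C[C@H](NC(=O)[C@@H]1CCCN1C)c1ccc(NC(=O)N2CC(c3cccnc3)C2)cc1` keeps the shared core and alters one group: 1-methylpyrrolidin-2-yl in place of oxan-4-yl on a carbonyl carbon. The new group, 1-methylpyrrolidin-2-yl, sits in place of oxan-4-yl on a carbonyl carbon.

Within the data shown here, the closest guide is the one measured swap at that same place, a 2.4-fold lower number from compound 2 to compound 3 (0.39 log units; beyond the scatter), which is a modest step. The other two steps, a 7.2-fold higher number from compound 1 to compound 2 (0.85 log units; beyond the scatter) and a 2.9-fold higher number from compound 1 to compound 3 (0.47 log units; beyond the scatter), are also modest, but each replaces a different group on a saturated chain carbon, so they bear on this change less directly. Among the measured compounds shown here, no measured compound carries 1-methylpyrrolidin-2-yl, and the data do not settle the direction. A modest rise, similar in size to the swap at the same place, is the expected outcome in this assay. The estimated change is a 2.1-fold higher number from compound 3 to compound 4 (0.32 log units; beyond the scatter). For compound 4 the expected value is 800000 nM, with an estimated range from 350000 nM to 1400000 nM.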

Compound 4, solubility: > 1000000 nM
Compound 4: a limit, no number; the forecaster's own chance of this, stated with the estimate: 25%; at least 1.2-fold (0.09 log units) between middle value and limit.
By their numbers in this assay, from the lowest: compound 1; then compound 3; then compound 2. At a limit, above all of these: compound 4.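

In this assay compound 4 gives a limit, not a number: the limit of > 1000000 nM in this assay, at which 1 of the 4 values shown sits.

Among these compounds, this is the first measured case of a ring nitrogen group at this place, on a carbonyl carbon whose other neighbour is an amide-type nitrogen, and the swap from oxan-4-yl to 1-methylpyrrolidin-2-yl gives an at least 2.6-fold higher number from compound 3 to compound 4 (0.42 log units; beyond the scatter), even though both groups hold the same counts of heavy atoms, donors and acceptors. Against the other two compounds the reading is uneven: the change of the whole group gives an at least 7.6-fold higher number from compound 1 to compound 4 (0.88 log units; beyond the scatter), while the swap from pyrimidin-2-yl gives an at least 1.0-fold higher number from compound 2 to compound 4 (0.03 log units; that floor lies within the scatter), so this floor alone does not separate compound 4 from compound 2.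

As far as these compounds go, what remains open is how far compound 4 lies past the limit, and so whether 1-methylpyrrolidin-2-yl truly differs from pyrimidin-2-yl at this place. The compounds shown also do not tell whether the same result would hold for pyrrolidin-2-yl without its methyl, for the opposite stereocentre of the ring, or for an open-chain amine such as dimethylaminomethyl on the same carbonyl carbon.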